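This account rests on a few compounds, and the source may have more. Where it says the series, first, only, none or still open, it means among the compounds named here.

Among the measured compounds shown here, compound 2 `CCCS(=O)(=O)N1CCN(c2ccc(OCC3CCN(C(=O)CC(C)(C)C)CC3)cn2)CC1` stands at the higher end of the two numbers measured so far in a functional assay on CHO-K1 cells for agonist activity at Glucose-dependent insulinotropic receptor (Homo sapiens), read by a luciferase reporter, with a stated time of 5 h; a higher number here means that more compound is needed for the effect, a lower number that less compound is needed: compound 2 gives 2800 nM, while compound 1 `CCCS(=O)(=O)N1CCN(c2ccc(OCC3CCN(C(=O)OC(C)C)CC3)cn2)CC1` gives 300 nM, and the gap between them lies well beyond the scatter. For the measured compounds named here, the one measured step, a 9.3-fold higher number from compound 1 to compound 2 (0.97 log units; beyond the scatter), is a change of the group on the carbonyl carbon. Compound 3 `CCCS(=O)(=O)N1CCN(c2ccc(OCC3CCN(C(=O)c4ccco4)CC3)cn2)CC1` changes that same place again, with furan-2-yl in place of neopentyl on a carbonyl carbon. Going by the values given here, the only step that bears on this change is a 9.3-fold higher number from compound 1 to compound 2 (0.97 log units; beyond the scatter), which shows that a swap on the carbonyl carbon can shift the number by a large margin. Among the compounds with values here, no measured compound carries an aromatic ring at this position, so the direction for furan-2-yl is not fixed by the data. Taking the one step as a sign that a change here tends to move the number beyond the scatter, and leaning towards the lower side since compound 1 gave 300 nM, the expected step for compound 3 is a 2.8-fold lower number from compound 2 to compound 3 (0.45 log units; beyond the scatter). Compound 3 is therefore estimated at 1000 nM, within a range from 250 nM to 4000 nM.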

Compound 3, half-maximal effective concentration: 2000 nM
Beside the measured number, compound 3's estimate is 2.0-fold (0.30 log units) below it; the measured number falls inside the stated range.
By their numbers in this assay, from the lowest: compound 1; then compounds 3 and 2 (each within the scatter of the next).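

In this assay, furan-2-yl in place of neopentyl on the carbonyl carbon gives a 1.4-fold lower number from compound 2 to compound 3 (0.15 log units; within the scatter), so a swap at this position need not move the number beyond the scatter, even when a five-membered aromatic ring with a hydrogen-bond acceptor replaces an open, ringless group of the same heavy-atom count. Furan-2-yl in place of isopropoxy gives a 6.7-fold higher number from compound 1 to compound 3 (0.82 log units; beyond the scatter), which means that two different groups, one aromatic and one not, now both stand apart from isopropoxy, and among these three compounds only compound 1, at 300 nM, holds the low number, with none going against this. No measured evidence is available to account for this result.

The compounds shown leave open whether the low number of compound 1 goes with the oxygen attached to the carbonyl carbon or with the branched isopropyl group beyond it, a question that ethoxy, tert-butoxy or an isopropylamino group at the same place would address. They also leave open whether other aromatic groups, such as phenyl or thiophen-2-yl, would read as furan-2-yl does here.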